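Swapping the aryl end of a chalcone-like core

The source may report more compounds than this note shows. Statements on the series, on what has been measured and on what is new or still open speak of the compounds shown alone.

Two compounds share a core built around a methoxy-bearing ring system carrying a double-bonded chain with a carbonyl. Compound 1 `COc1ccc(C(=O)/C=C/c2ccc(F)cc2)c2c1C=CC(C)(C)O2` carries a 4-fluorophenyl on the chain end. In a functional assay on HCT-116 cells (Homo sapiens) for antiproliferative activity, read by MTT assay, with a stated time of 24 h (a higher number here means a weaker inhibitor, a lower number a stronger inhibitor), compound 1 gives only a limit, > 10000 nM. Compound 2 `COc1ccc(C(=O)/C=C/c2cccs2)c2c1C=CC(C)(C)O2` carries thiophen-2-yl in that place. In this assay compound 2 also reaches only a limit, > 10000 nM. The step that the two limits leave unreadable from compound 1 to compound 2 cannot be read, since both ends sit at the limit (the limit of > 10000 nM in this assay, at which 2 of the 2 values shown sit).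

Compound 3 `COc1ccc(C(=O)/C=C/c2ccc(O)c(Br)c2)c2c1C=CC(C)(C)O2` is the next compound; (3-bromo-4-hydroxyphenyl in place of thiophen-2-yl on a double-bonded chain carbon bound to a double-bonded chain carbon). Nothing measured so far separates one aryl end from another here, so no direction can be drawn from the single step shown. The expectation is that compound 3 stays near the limit, with the step from compound 2 estimated as a step that the limit leaves unreadable from compound 2 to compound 3. For compound 3 the estimate in this assay is 12000 nM, within a range from 3000 nM to 50000 nM, and a limit rather than a number is the more likely outcome.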

Compound 3, half-maximal inhibitory concentration: > 10000 nM
Compound 3 ended at the assay's limit; the forecaster's own chance of this, stated with the estimate: 70%; the middle value lies beyond the limit too.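

Compound 3 also ends at a limit rather than a number, so the steps to it from compound 1 and from compound 2 cannot be read: the limit of > 10000 nM in this assay, at which 3 of the 3 values shown sit.

The three compounds leave open whether any aryl end on the shared core gives a measurable value in this assay, and how such ends would rank against one another.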